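Swapping an Acetyl for Iodo on a Urea Series

A few compounds are considered here, and "the series" means these few. Any claim that something is new, unique, unknown or untested is made for them only; others in the source may bear on it.

Of the compounds shown here, three that share one core have been measured in an ADME assay on the whole organism with Oryza sativa as the target, tested at 10 uM; a higher number here means a weaker effect of the compound at the concentration tested, a lower number a stronger effect. Compound 1 `C[C@H](NC(=O)Nc1ccccc1C(C)(C)C)c1ccccc1` gives 100%. Compound 2 `C[C@H](NC(=O)Nc1ccccc1C(F)(F)F)c1ccccc1` gives 97%, and compound 3 `CC(=O)c1ccccc1NC(=O)N[C@@H](C)c1ccccc1` gives 96%. Compound 3 carries the lowest of the three numbers, yet every gap is small: a number 4 percentage points lower from compound 1 to compound 3 (within the scatter) and a number 1 percentage points lower from compound 2 to compound 3 (within the scatter), just as a number 3 percentage points lower from compound 1 to compound 2 (within the scatter).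

Compound 4 `C[C@H](NC(=O)Nc1ccccc1I)c1ccccc1` has not yet been measured. It differs from compound 3 by iodo in place of acetyl on an aromatic carbon.

Within the data shown here, no measured step introduces iodo, so none bears on this change directly. What the three steps do show is that exchanging the group at this aromatic carbon, whether for trifluoromethyl or for acetyl, left the read-out within the scatter each time. On that basis the expected change is no change at the digits printed from compound 3 to compound 4 (within the scatter), that is, no step beyond the scatter. Compound 4 is therefore estimated at 96%, with a range from 82% to 100%.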

Compound 4, a percentage reported as activity, at one concentration (the size of the read-out at that concentration, not a potency): 98%
Estimate against measurement, compound 4: 2 percentage points below; the measured number falls inside the stated range.
By their numbers in this assay, from the lowest: compounds 3, 2, 4 and 1 (each within the scatter of the next).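

Iodo brings a single iodine atom where acetyl had 3 heavy atoms and 1 hydrogen-bond acceptor, yet this assay shows a number 2 percentage points higher from compound 3 to compound 4 (within the scatter). The comparisons with the other two groups read the same way, with a number 1 percentage points higher from compound 2 to compound 4 (within the scatter) and a number 2 percentage points lower from compound 1 to compound 4 (within the scatter). A lone halogen atom therefore joins tert-butyl, trifluoromethyl and acetyl as a fourth group at this aromatic carbon with no step beyond the scatter, and no measurement available here accounts for that lack of change.

From the compounds shown here alone, whether an amine or a carboxylic acid on this aromatic carbon would move the number beyond the scatter remains open. Also open, going by these compounds, is whether iodo or acetyl would give the same read-out on a different carbon of this ring.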